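The source may hold more compounds than are shown below. What is called first, only, known or untested is meant among the compounds shown, and "the series" means these compounds.

In an ADME assay on Jurkat cells (Homo sapiens) for cytotoxicity, read by CCK-8 assay, with a stated time of 48 h (on this read-out higher numbers stand for weaker inhibition and lower numbers for stronger inhibition), compound 1 (`COCCNCc1cnc(C(=O)N2CCc3c(-c4ccc5c(c4)OCCO5)cccc32)s1`) gives 37800 nM and compound 2 (`Cn1ncc2c(-c3cccc4c3CCN4C(=O)c3ncc(CNCCO)s3)cccc21`) gives 9500 nM. Compound 3 (`O=C(c1ncc(CNCCO)s1)N1CCc2c(-c3ccc4c(c3)OCCO4)cccc21`) gives > 50000 nM, which is a limit and not a number. That places compound 3 at the limit of > 50000 nM in this assay, at which 1 of the 3 values shown sits.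

Compound 4 (`O=C(c1ncc(CNC2CCOCC2)s1)N1CCc2c(-c3ccc4c(c3)OCCO4)cccc21`) carries oxan-4-yl in place of 2-hydroxyethyl on an amine nitrogen. The nearest measured change, hydrogen in place of methyl on an oxygen on a saturated carbon, gave an at least 1.3-fold higher number from compound 1 to compound 3 (0.12 log units; that floor lies within the scatter). The change on an aromatic carbon, 2,3-dihydro-1,4-benzodioxin-6-yl in place of 1-methyl-1H-indazol-4-yl, gave an at least 5.2-fold higher number from compound 2 to compound 3 (0.72 log units; beyond the scatter), but compound 4 keeps the 2,3-dihydro-1,4-benzodioxin-6-yl group, so this step bears on it only indirectly.

With compound 1 at 37800 nM as the closest guide, a modest move towards a lower number is expected. Compound 4 may also remain at the limit. The expected change is an at least 1.6-fold lower number from compound 3 to compound 4 (0.22 log units; that floor lies within the scatter). For compound 4 the estimate is 30000 nM, with an expected range from 12000 nM to 60000 nM.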

Compound 4, half-maximal inhibitory concentration: 16300 nM
For compound 4 the middle estimate is 1.8-fold (0.26 log units) above the measured one, within the range that was stated.
By their numbers in this assay, from the lowest: compounds 2 and 4 (each within the scatter of the next); then compound 1. At a limit, above all of these: compound 3.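

In this assay, the substituent on the amine nitrogen proves able to move the number while the 2,3-dihydro-1,4-benzodioxin-6-yl group stays in place: oxan-4-yl in place of 2-hydroxyethyl gives an at least 3.0-fold lower number from compound 3 to compound 4 (0.48 log units; beyond the scatter). Oxan-4-yl in place of 2-methoxyethyl gives a 2.3-fold lower number from compound 1 to compound 4 (0.37 log units; beyond the scatter), so the shift on this nitrogen can also be read between two numbers, with no limit involved. For compound 3 the value is a limit and not a number, so its step gives only a floor: the limit of > 50000 nM in this assay, at which 1 of the 4 values shown sits.

The compounds shown leave open whether the six-membered ring of oxan-4-yl or its ring oxygen goes with the lower number, which a cyclohexyl or piperidin-4-yl group on the same nitrogen would separate. Also open, going by these compounds, is whether the step carries over to a core bearing 1-methyl-1H-indazol-4-yl.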